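Replacing the hydroxy group of compound 2 with hydrogen

The compounds below may be only part of what the source reports. "The series", "measured", "known", "first", "only" and "open" are said of these compounds alone.

Measured so far in a functional assay on PC-3 cells (Homo sapiens) for antiproliferative activity, read by luminescence, with a stated time of 96 h; on this read-out lower numbers stand for stronger inhibition and higher numbers for weaker inhibition
- compound 1 `COc1cc2c(cc1NS(=O)(=O)c1cc(Br)ccc1OC)OC(C)(C)C(=O)N2` gives 17200 nM
- compound 2 `COc1ccc(Br)cc1S(=O)(=O)Nc1cc2c(cc1O)NC(=O)C(C)(C)O2` gives 22900 nM

Compound 2 lies within the scatter of compound 1 and the two values give no order. Not yet measured is compound 3 `COc1ccc(Br)cc1S(=O)(=O)Nc1ccc2c(c1)OC(C)(C)C(=O)N2` with hydrogen in place of hydroxy on an aromatic carbon as its only difference from compound 2. Among the measured compounds shown here, one measured step bears on this carbon: hydrogen in place of methyl on an oxygen on an aromatic ring, which gave a 1.3-fold higher number from compound 1 to compound 2 (0.12 log units; within the scatter) in this assay here. For the measured compounds named here, no measured step removes that oxygen altogether, so the evidence is indirect. With compound 2 at 22900 nM as the anchor, no step beyond the scatter is expected in this assay for this change. The expected step is a 1.3-fold lower number from compound 2 to compound 3 (0.10 log units; within the scatter) as an estimate only. Compound 3 is estimated at 18000 nM with an expected range from 7000 nM to 45000 nM for now.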

Compound 3, half-maximal inhibitory concentration: 21000 nM
Beside the measured number, compound 3's estimate is 1.2-fold (0.07 log units) below it; the measured number falls inside the stated range.
By their numbers in this assay, from the lowest: compounds 1, 3 and 2 (each within the scatter of the next).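

In this assay, taking the oxygen off this aromatic carbon altogether does not move the number beyond the scatter: hydrogen in place of hydroxy gives a 1.1-fold lower number from compound 2 to compound 3 (0.04 log units; within the scatter), and hydrogen in place of methoxy gives a 1.2-fold higher number from compound 1 to compound 3 (0.09 log units; within the scatter). Among the compounds shown here, the earlier pair compared only two oxygen-linked groups, whereas compound 3 adds the bare carbon, so hydroxy, methoxy and hydrogen at this position now show no order, and an oxygen here is not required for a number at this level. No data are available that would account for these three groups reading alike.

Still open, on these data alone, is whether any group on this carbon moves the number beyond the scatter, for example an amine, a carboxylic acid or a longer alkoxy chain. As far as these compounds go, all three compounds share the rest of the core, so the effect of changes elsewhere on it also remains open.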